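Chloro to nitro on the pendant ring at two positions

This account rests on a few compounds, and the source may have more. Where it says the series, first, only, none or still open, it means among the compounds named here.

Compound 1 `Clc1ccc(-c2nnc(Nc3ncccn3)o2)cc1` and compound 2 `Clc1ccccc1-c1nnc(Nc2ncccn2)o1` are built from the same atoms joined differently; the difference between the two cores is not broken down here. In a functional assay, with a stated time of 30 min, tested at 20 uM (on this read-out higher numbers stand for more inhibition at the one concentration tested (going by the name of the read-out) and lower numbers for less inhibition), compound 1 gives 46.2%. Compound 2 in this assay returns only the limit of the assay, < 20%. Compound 3 `O=[N+]([O-])c1ccc(-c2nnc(Nc3ncccn3)o2)cc1` carries nitro in place of chloro on an aromatic carbon. Compound 3 in this assay likewise returns only the limit, < 20%. Within the data shown here, the one measured example of this change is the step of a number at least 26.2 percentage points lower from compound 1 to compound 3 (beyond the scatter), and its true size is open at one end because the limit of < 20% in this assay, at which 2 of the 3 values shown sit, caps what the assay reports. Compound 4 `O=[N+]([O-])c1ccccc1-c1nnc(Nc2ncccn2)o1` carries nitro in place of chloro on an aromatic carbon, the same kind of change as that from compound 1 to compound 3, though here the place is ortho to a large group rather than para to a large group. Since compound 2 already sits at the limit with < 20%, the step that the limit leaves unreadable from compound 2 to compound 4 is expected to be small or unresolved. Compound 4 is therefore expected near 10%, between 0% and 22%, most probably reported only as the limit.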

Compound 4, a percentage reported as inhibition, at one concentration (the size of the read-out at that concentration, not a potency): 51.8%
The estimate for compound 4 lay 41.8 percentage points below the measured number; the whole stated range lies below it.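

In this assay, nitro in place of chloro, here ortho to a large group, gives a number at least 31.8 percentage points higher from compound 2 to compound 4 (beyond the scatter), so the same change does not carry over in one direction between these two cores, as the comparison with the earlier step shows: the same change on two cores in this assay, a number at least 26.2 percentage points lower (beyond the scatter) from compound 1 to compound 3 and a number at least 31.8 percentage points higher (beyond the scatter) from compound 2 to compound 4, at least 58 percentage points apart, beyond the scatter of two such steps Neither step has a fully known size, and the gap between them is known only from one side: the limit of < 20% in this assay, at which 2 of the 4 values shown sit. With a single pair on each core, and the group in a different place in each pair, these data do not separate the effect of the core from that of the place, and they give no general rule for this change across the series.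

Still open, as far as these compounds go, is whether an amine or a carboxylic acid in the same place on the pendant ring would follow nitro or chloro. Among these compounds, also open is whether nitro ortho to a large group keeps this direction on any core beyond the one in compound 4.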